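The source may report more compounds than this note shows. Statements on the series, on what has been measured and on what is new or still open speak of the compounds shown alone.

Measured so far in an ADME assay (liver) for metabolic stability, with Liver microsome (Rattus norvegicus) as the target, using microsomes; a lower number here means slower removal, a higher number faster removal of the compound
- compound 1 `c1ccc(CNc2nnc(-c3c[nH]c4ncccc34)o2)cc1` gives 40 mL.min-1.g-1
- compound 2 `c1ccc(CNc2nnc(-c3c[nH]c4ncccc34)o2)nc1` gives 14 mL.min-1.g-1
- compound 3 `c1cnc2[nH]cc(-c3nnc(NCc4ccncc4)o3)c2c1` gives 37 mL.min-1.g-1

Compound 1 stands at the high end of these three numbers. The nearest measurement is a 1.1-fold lower number from compound 1 to compound 3 (0.03 log units; within the scatter) and the furthest is a 2.9-fold lower number from compound 1 to compound 2 (0.46 log units; beyond the scatter) in this series.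

Compound 4 `CC[C@@H](Nc1nnc(-c2c[nH]c3ncccc23)o1)c1ccccc1` keeps the phenyl and changes the chain carbon instead: ethyl in place of hydrogen on a saturated chain carbon bound to an aromatic carbon and a nitrogen on an aromatic ring is the whole difference.

The measured steps only exchange the ring on that chain carbon, and none of them adds a group there. The largest of them are the step above and a 2.6-fold higher number from compound 2 to compound 3 (0.42 log units; beyond the scatter) so they give a rough sense of how far one change moves the number here, but no direct guide to the ethyl group. The data therefore give no firm direction, and the estimate stays close to compound 1 at 40 mL.min-1.g-1 with a slight upward lean that is judgement only.

The expected step is a 1.4-fold higher number from compound 1 to compound 4 (0.14 log units; within the scatter) and no larger shift is anticipated.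

Compound 4 is estimated at 55 mL.min-1.g-1 with an expected range of 22 mL.min-1.g-1 to 130 mL.min-1.g-1 in this assay as the working figure.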

Compound 4, intrinsic clearance in microsomes: 29 mL.min-1.g-1
For compound 4 the middle estimate is 1.9-fold (0.28 log units) above the measured one, within the range that was stated.
By their numbers in this assay, from the lowest: compound 2; then compounds 4, 3 and 1 (each within the scatter of the next).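

In this assay, among these compounds, ethyl in place of hydrogen on the saturated chain carbon bound to an aromatic carbon and a nitrogen on an aromatic ring gives a 1.4-fold lower number from compound 1 to compound 4 (0.14 log units; within the scatter) and so provides the first reading of a group added at that carbon, as the earlier steps only exchanged the ring on it. With the phenyl kept, this carbon takes an ethyl group without a shift beyond the scatter, whereas the ring exchange in a 2.9-fold lower number from compound 1 to compound 2 (0.46 log units; beyond the scatter) remains the step from compound 1 that lies beyond it. No supporting measurement is available to explain this result.

Going by these compounds, whether a methyl, a longer chain or an amine at this carbon would also stay within the scatter remains open. Also open, on these data alone, are the opposite configuration at this carbon and the effect of ethyl when pyridin-2-yl replaces the phenyl.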